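The compounds below may be only part of what the source reports. "The series", "measured", "known", "first", "only" and "open" are said of these compounds alone.

Measured so far:
- Compound 1 `COC(=O)c1c(Nc2ccc(F)cc2)sc(C(=O)c2ccc(OC)cc2)c1C`: 14%
- Compound 2 `COc1ccc(C(=O)c2sc(Nc3ccc(C)cc3)c(C(=O)O)c2C)cc1`: "not active" (no number reported)

In a functional assay, with a stated time of 150 min, tested at 10 ug/mL (on this read-out higher numbers stand for a stronger effect at the one concentration tested and lower numbers for a weaker effect), compound 1 gives 14%, a small effect at the one concentration tested. Compound 2 is reported in this assay as "not active" (no number reported), with no number attached, so it cannot be placed on the scale; all that is known is that no measurable effect was seen for compound 2.

Compound 3 `COc1ccc(C(=O)c2sc(Nc3ccc(F)cc3)c(C(=O)O)c2C)cc1` is the one still to be measured. It differs from compound 2 in a single place: fluoro in place of methyl on an aromatic carbon. Among the measured compounds shown here, no step between two measured compounds covers this change, so its size is not known from the data. Given that compound 2 shows no measured effect, the step in this assay is expected to be small, and most likely to stay within the usual scatter, in either direction or none at all. Compound 3 is expected to give about 8% in this assay, within a range from 0% to 22%.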

Compound 3, a percentage reported as activity, at one concentration (the size of the read-out at that concentration, not a potency): 0.98%
Estimate against measurement, compound 3: 7 percentage points above; the measured number falls inside the stated range.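

In this assay compound 3 gives 0.98% and so carries a number, while compound 2 has none, which means the step from 4-methylphenyl to 4-fluorophenyl cannot be read as a size. Among the compounds shown here, with the (4-fluorophenyl)amino group held constant, hydrogen in place of the methyl on the ester oxygen gives a number 13 percentage points lower from compound 1 to compound 3 (beyond the scatter) and turns the methyl ester into a carboxylic acid, the first change with a readable size. Nothing measured here accounts for that drop.

Still open, from the compounds shown here alone, is whether a chloro group on the same aromatic carbon would behave like fluoro in the acid series. Also open, going by these compounds, is whether an ethyl ester or a primary amide in place of the carboxylic acid would hold or raise the effect seen with the methyl ester.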